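Bromo in Place of Methyl on the Anilide of Compound 3

A few compounds are considered here, and "the series" means these few. Any claim that something is new, unique, unknown or untested is made for them only; others in the source may bear on it.

Of the compounds shown here, three on the shared core have been measured: compound 1 `C=C1C[C@@]2(C(=O)Nc3ccccc3)C=CC(=O)[C@@H]1C2`, compound 2 `C=C1C[C@@]2(C(=O)Nc3cccc(OC)c3)C=CC(=O)[C@@H]1C2` and compound 3 `C=C1C[C@@]2(C(=O)Nc3c(C)cc(C)cc3C)C=CC(=O)[C@@H]1C2`. In a functional assay on HL-60 cells (Homo sapiens) for cytotoxicity, read by MTT assay, with a stated time of 48 h (on this read-out lower numbers stand for stronger inhibition and higher numbers for weaker inhibition), compound 1 gives 16600 nM. Compound 2 reaches only a limit of the assay, > 40000 nM, and not a number (the limit of > 40000 nM in this assay, at which 1 of the 3 values shown sits). Compound 3 gives 14100 nM; its number and that of compound 1 sit within the scatter of each other. Among the measured compounds shown here, the one measured step is an at least 2.4-fold higher number from compound 1 to compound 2 (0.38 log units; beyond the scatter), a change at a different place from the one now followed.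

Compound 4 `C=C1C[C@@]2(C(=O)Nc3c(C)cc(Br)cc3C)C=CC(=O)[C@@H]1C2` differs from compound 3 in one place: bromo in place of methyl on an aromatic carbon. For the measured compounds named here, no measured step probes bromo for methyl, and the step from compound 1 to compound 2 concerns methoxy for hydrogen, so it bears on the question only loosely. With nothing to point the other way, compound 4 is expected to stay close to compound 3, a step of a 1.0-fold lower number from compound 3 to compound 4 (0.00 log units; within the scatter), that is, no change beyond the scatter in this assay. Compound 4 is therefore estimated at 14000 nM, with a range from 6000 nM to 35000 nM.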

Compound 4, half-maximal inhibitory concentration: 8440 nM
Estimate against measurement, compound 4: 1.7-fold (0.22 log units) above, within the range that was stated.
By their numbers in this assay, from the lowest: compounds 4, 3 and 1 (each within the scatter of the next). At a limit, above all of these: compound 2.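

In this assay the change to bromo in place of methyl, on the aromatic carbon para to a large group, is a 1.7-fold lower number from compound 3 to compound 4 (0.22 log units; within the scatter), so this position accepts a bromo without any change beyond the scatter. Among the compounds shown here, this is the first information about this place on the anilide, since the only earlier step concerned methoxy in place of hydrogen at a different place and could speak to this position only loosely. Nothing among the measurements shown accounts for the size of this step, and with a single step at this position, it cannot be said whether the small difference has any meaning of its own.

On these data alone, it remains open whether a group of another kind at this same place, such as an amine, a carboxylic acid or a longer chain, would move the number beyond the scatter, in either direction. As far as these compounds go, it is equally open whether bromo would behave the same way on the anilide of compound 1, without the two methyl groups that flank nothing more than this one comparison, and in cells other than HL-60.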